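This account rests on a few compounds, and the source may have more. Where it says the series, first, only, none or still open, it means among the compounds named here.

The measured compounds: compound 1 `CCN(C)C(=O)/C=C1\CCc2c(F)cc(F)cc21` with 56 mg/kg; compound 2 `CN(C)C(=O)/C=C1\CCc2c(F)cc(F)cc21` with 50 mg/kg; compound 3 `CCNC(=O)/C=C1\CCc2ccc(F)cc21` with 70 mg/kg, all in a functional assay on the whole organism with Mus musculus as the target; on this read-out lower numbers stand for an effect already at smaller amounts and higher numbers for an effect only at larger amounts of compound.

Compound 4 `CC(C)NC(=O)/C=C1\CCc2ccc(F)cc21` is not yet measured. It differs from compound 3 by methyl in place of hydrogen on a saturated chain carbon bound to an amide-type nitrogen and a saturated chain carbon. Compounds 1 and 2 show the same kind of change, (methyl in place of hydrogen on a saturated chain carbon bound to an amide-type nitrogen), the only difference around the place being that in compound 4 the carbon is also bound to a saturated chain carbon. That step gave a 1.1-fold higher number from compound 2 to compound 1 (0.05 log units; within the scatter). The difference between the cores of compound 3 and compound 2 is not broken down here, and the values of compound 3 against compounds 1 and 2 lie within the scatter. On this basis the step from compound 3 to compound 4 is expected to be small, a 1.1-fold higher number from compound 3 to compound 4 (0.03 log units; within the scatter), because the earlier one was a 1.1-fold higher number from compound 2 to compound 1 (0.05 log units; within the scatter). Compound 4 is therefore estimated at 75 mg/kg, most likely between 40 mg/kg and 140 mg/kg.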

Compound 4, dose for half-maximal effect: 96 mg/kg
Estimate against measurement, compound 4: 1.3-fold (0.11 log units) below; the measured number falls inside the stated range.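

In this assay the methyl in place of hydrogen on the saturated chain carbon gave a 1.4-fold higher number from compound 3 to compound 4 (0.14 log units; within the scatter) on the core of compound 3. Set beside the earlier step, the change carries from one core to the other with no gap that can be told from the scatter: the same change on two cores in this assay, a 1.1-fold higher number (0.05 log units; within the scatter) from compound 2 to compound 1 and a 1.4-fold higher number (0.14 log units; within the scatter) from compound 3 to compound 4, 1.2-fold (0.09 log units) apart, within the scatter of two such steps. For the compounds shown here, this rests on only two pairs, and neither step lies beyond the scatter, so it shows no real effect of the change on either core and says nothing about other cores.

The compounds shown leave open what a longer chain, such as butyl, or a ring, such as cyclopropyl, would do in place of ethyl or isopropyl. They also leave open whether an amide without any chain on its nitrogen would fit the same narrow range.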